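Tetrahydroquinoline against tetrahydroisoquinoline in a calpain inhibitor series

This account rests on a few compounds, and the source may have more. Where it says the series, first, only, none or still open, it means among the compounds named here.

Measured so far in an assay on isolated protein (Oryctolagus cuniculus) for inhibition of Calpain-2 catalytic subunit (Homo sapiens); a higher number here means a weaker inhibitor, a lower number a stronger inhibitor:
- compound 1 `CCC(NC(=O)C(CC(C)C)NC(=O)OCc1ccccc1)C(=O)C(=O)NCc1ccc2ccccc2n1` gives 600 nM
- compound 2 `CCC(NC(=O)C(CC(C)C)NC(=O)OCc1ccccc1)C(=O)C(=O)NCCCN1CCCc2ccccc21` gives 200 nM

Among the measured compounds shown here, compound 2 stands at the lowest of the two numbers; the one measured step in this assay is a 3.0-fold lower number from compound 1 to compound 2 (0.48 log units; beyond the scatter). Compound 3 `CCC(NC(=O)C(CC(C)C)NC(=O)OCc1ccccc1)C(=O)C(=O)NCCCN1CCc2ccccc2C1` is the next variation on compound 2: 1,2,3,4-tetrahydroisoquinolin-2-yl in place of 1,2,3,4-tetrahydroquinolin-1-yl on a saturated chain carbon, three bonds along the chain from an amide-type nitrogen. The measured step bears only loosely on this: it exchanged an aromatic ring placed directly on the chain carbon for a saturated ring on a longer chain, whereas the change to compound 3 keeps chain length, ring count and atom count and only moves the point at which the bicyclic ring is joined. For the measured compounds named here, no measured pair tests such a rearrangement. The expectation is therefore a step of no more than the scatter in this assay, in no preferred direction: compound 3 is estimated at 250 nM, with a range from 100 nM to 700 nM. The step this estimate implies is a 1.3-fold higher number from compound 2 to compound 3 (0.10 log units; within the scatter).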

Compound 3, inhibition constant: 190 nM
The estimate for compound 3 lay 1.3-fold (0.12 log units) above the measured number; low and high end bracket the measured number.
By their numbers in this assay, from the lowest: compounds 3 and 2 (each within the scatter of the next); then compound 1.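

In this assay, changing the point at which the bicyclic ring is joined, with 1,2,3,4-tetrahydroisoquinolin-2-yl in place of 1,2,3,4-tetrahydroquinolin-1-yl, gives a 1.1-fold lower number from compound 2 to compound 3 (0.02 log units; within the scatter), so the two ring joinings cannot be told apart at this place. The 2-(1,2,3,4-tetrahydroisoquinolin-2-yl)ethyl group in place of quinolin-2-yl gives a 3.2-fold lower number from compound 1 to compound 3 (0.50 log units; beyond the scatter), close in size to a 3.0-fold lower number from compound 1 to compound 2 (0.48 log units; beyond the scatter), so in these compounds the step from compound 1 does not depend on which of the two joinings is present. Nothing available here accounts for this match between the two joinings.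

Still open, on these data alone, is whether the match holds on a shorter or a longer chain. As far as these compounds go, it is also open whether an open-chain dimethylamino group on the same chain would give a number close to those of compound 2 and compound 3.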